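The source may hold more compounds than are shown below. What is called first, only, known or untested is meant among the compounds shown, and "the series" means these compounds.

Compound 1 `C[S+]([O-])c1c(F)c(N)c2c(=O)cc(-c3ccc(N)c(F)c3)oc2c1F` gives 2500 nM in a functional assay on MCF7 cells (Homo sapiens) for cytotoxicity, read by neutral red uptake, with a stated time of 3 days; on this read-out lower numbers stand for stronger inhibition and higher numbers for weaker inhibition. Compound 2 `Nc1ccc(-c2cc(=O)c3c(N)c(F)c(O)c(F)c3o2)cc1F` gives > 10000 nM in this assay, which is a limit of the assay and not a number. Compound 3 `CCOC(=O)c1c(F)c(N)c2c(=O)cc(-c3ccc(N)c(F)c3)oc2c1F` gives 1400 nM in this assay.

Among the two numbers obtained, compound 3 has the lower one, but the step of a 1.8-fold lower number from compound 1 to compound 3 (0.25 log units; within the scatter) lies within the scatter, so no order between compound 1 and compound 3 can be read from it.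

Compound 4 `CCCCCC(=O)NCc1c(F)c(N)c2c(=O)cc(-c3ccc(N)c(F)c3)oc2c1F` differs from compound 3 at one place: ((pentylcarbonyl)amino)methyl in place of ethoxycarbonyl on an aromatic carbon. Within the data shown here, two measured steps concern the same aromatic carbon. The step of a 1.8-fold lower number from compound 1 to compound 3 (0.25 log units; within the scatter) exchanged one uncharged group for another and stayed within the scatter. The step of an at least 7.1-fold lower number from compound 2 to compound 3 (0.85 log units; beyond the scatter) was the only one beyond the scatter, and it started from a compound whose value was the limit of > 10000 nM in this assay, at which 1 of the 3 values shown sits. Compound 4 again carries an uncharged chain at this carbon and no hydroxy, so the change is expected to resemble the first of these steps rather than the second, with the number for compound 4 expected to move a 1.8-fold higher number from compound 3 to compound 4 (0.25 log units; within the scatter), a step within the scatter or a modest rise. Compound 4 is therefore estimated at 2500 nM in this assay, with a range from 800 nM to 8000 nM.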

Compound 4, half-maximal inhibitory concentration: 340 nM
Compound 4: middle estimate off by 7.4-fold (0.87 log units), on the high side, and the stated range ends above it.
By their numbers in this assay, from the lowest: compound 4; then compounds 3 and 1 (each within the scatter of the next). At a limit, above all of these: compound 2.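

At this aromatic carbon, ortho to two fluoro groups, swapping one uncharged group for another had stayed within the scatter, but in this assay the ((pentylcarbonyl)amino)methyl group gives a 4.1-fold lower number from compound 3 to compound 4 (0.61 log units; beyond the scatter) and a 7.4-fold lower number from compound 1 to compound 4 (0.87 log units; beyond the scatter). Both steps lie beyond the scatter, so the choice among uncharged groups at this carbon can matter, and a group of this size is compatible with the lowest number in the set; a hydrogen-bond donor alone does not account for that, since compound 2, with its hydroxy group, goes the other way. The change also appears as an at least 29-fold lower number from compound 2 to compound 4 (1.46 log units; beyond the scatter), but compound 2 stands at a limit and not at a number, so this step sets only a minimum size: the limit of > 10000 nM in this assay, at which 1 of the 4 values shown sits.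

The entering group differs from the ethoxycarbonyl group in its amide link and in its pentyl chain at once, and the compounds shown do not separate these two features. On these data alone, whether a shorter acetyl amide, a longer chain, a free amine or a carboxylic acid at this carbon would lower the number further or raise it remains open.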